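The source may report more compounds than this note shows. Statements on the series, on what has been measured and on what is new or still open speak of the compounds shown alone.

Working notes on the series. Compound 1 `COc1cccc(-c2nc(SCC(=O)c3sc(-c4ccccc4)nc3C)[nH]c(=O)c2C#N)c1` and compound 2 `Cc1nc(-c2ccc(Cl)cc2)sc1C(=O)CSc1nc(-c2ccc(Cl)c(Cl)c2)c(C#N)c(=O)[nH]1` are the two measured members; in a functional assay on U-87MG ATCC cells for antiproliferative activity against U-87 MG (Homo sapiens), read by MTT assay, with a stated time of 48 h, tested at 50 uM (a higher number here means a weaker effect of the compound at the concentration tested, a lower number a stronger effect), compound 1 gives 80.3%, and in this assay compound 2 gives 93.9%, the higher of the two numbers shown, with compound 1 lying lower by a margin beyond the usual scatter. Compound 3 `Cc1nc(-c2ccccc2)sc1C(=O)CSc1nc(-c2ccc(Cl)c(Cl)c2)c(C#N)c(=O)[nH]1` has not been measured. It differs from compound 2 in one place: hydrogen in place of chloro on an aromatic carbon. Among the measured compounds shown here, no pair of measured compounds differing in only this one place exists, so the size of this step has no direct precedent; compound 1 carries a phenyl on the same side but differs from compound 3 elsewhere as well, so only its own value can be read from it. The step from compound 2 to compound 3 is expected to be small, most likely within scatter or a modest move toward a lower number, a number 5.9 percentage points lower from compound 2 to compound 3 (within the scatter). Compound 3 is thus estimated at 88%, with a range from 74% to 99%.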

Compound 3, a percentage reported as activity, at one concentration (the size of the read-out at that concentration, not a potency): 75.3%
Compound 3: the middle estimate sits 12.7 percentage points above what was measured; the range from low to high includes it.
By their numbers in this assay, from the lowest: compounds 3 and 1 (each within the scatter of the next); then compound 2.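

In this assay, among the compounds shown here, hydrogen in place of chloro, the change from 4-chlorophenyl to phenyl, gives a number 18.6 percentage points lower from compound 2 to compound 3 (beyond the scatter) and so provides the first direct reading at this place on the ring, showing that the read-out responds to this single-atom change and that the phenyl compound has the stronger effect. With the phenyl held constant, 3,4-dichlorophenyl in place of 3-methoxyphenyl gives a number 5 percentage points lower from compound 1 to compound 3 (within the scatter) and so shows no resolved effect of that exchange in this assay. Nothing in the data shown accounts for the size of the chloro step.

From the compounds shown here alone, it remains open whether a fluoro, a methyl or an amino group at the same place would read closer to the chloro or the hydrogen compound. Going by these compounds, it is also open whether the step from 4-chlorophenyl to phenyl holds when 3-methoxyphenyl sits on the other side of the molecule.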